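Working notes: the step from compound 1 to compound 4

The compounds below may be only part of what the source reports. "The series", "measured", "known", "first", "only" and "open" are said of these compounds alone.

Compound 1 `CC(C)(C)CC(=O)Nc1cccc(C(=O)N2CCCC(C(=O)Nc3ccc(Cl)cc3)C2)c1` is one of three measured members of the series. In an ADME assay on PC-3 cells (Homo sapiens) for cytotoxicity, read by WST assay, tested at 100 uM (a lower number here means less inhibition, a higher number more inhibition at the concentration tested (going by the name of the read-out)), compound 1 gives 0%. Compound 2 `O=C(Nc1cccc(OCCc2ccccn2)c1)C1CCCN(C(=O)c2cc(C(F)(F)F)cc(C(F)(F)F)c2)C1` gives 5% and compound 3 `O=C(Nc1cccc(S(=O)(=O)N2CCCC2)c1)C1CCCN(C(=O)c2cc(C(F)(F)F)cc(C(F)(F)F)c2)C1` gives 0%. Among the compounds with values here, the single measured step, a number 5 percentage points lower from compound 2 to compound 3 (within the scatter), stays within the scatter. Compound 1 and compound 3 read the same at the digits shown, and compound 2 lies within the scatter of both, so the three values cannot be separated.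

Compound 4 `COc1cccc(C(=O)N2CCCC(C(=O)Nc3ccc(Cl)cc3)C2)c1` differs from compound 1 by the change (methoxy in place of (neopentylcarbonyl)amino on an aromatic carbon). Within the data shown here, no measured pair shows this change or touches this position; the one measured step concerns a substituent on a different ring and was itself within the scatter. The data therefore offer no ground for a step beyond the scatter in this assay in either direction. The expectation is that the step of a number 2 percentage points higher from compound 1 to compound 4 (within the scatter) stays within the scatter, and compound 4 is estimated at 2%, with a range from 0% to 12%, resting on the flat readings of compound 1, compound 2 and compound 3.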

Compound 4, a percentage reported as inhibition, at one concentration (the size of the read-out at that concentration, not a potency): 0%
Beside the measured number, compound 4's estimate is 2 percentage points above it; the range from low to high includes it.
By their numbers in this assay, from the lowest: compounds 1, 3, 4 and 2 (each within the scatter of the next).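

In this assay, within the data shown here, methoxy in place of (neopentylcarbonyl)amino on an aromatic carbon gives no change at the digits printed from compound 1 to compound 4 (within the scatter), and this is the first reading at this position, since the earlier step concerned a substituent elsewhere. For this pair, exchanging a group of 8 heavy atoms with 1 hydrogen-bond donor for one of 2 heavy atoms with 0 hydrogen-bond donors leaves no difference that can be separated in this read-out, so the large amide group is not needed to keep the reading where compound 1 has it. No supporting measurement accompanies the result to account for this flat step.

A single replacement at one place on the core of compound 1 leaves open whether an amine, a carboxylic acid or a longer alkyl chain at this position would give a step beyond the scatter in this assay. Also open is whether methoxy would give the same flat step on the cores that carry two trifluoromethyl groups, as no pair with this change on those cores is shown.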